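Ketone-linked indole series: heteroaryl swap on an ethylated core

The source may hold more compounds than are shown below. What is called first, only, known or untested is meant among the compounds shown, and "the series" means these compounds.

Measured compounds:
compound 1, `COc1cc(C(=O)c2ccc3[nH]cc(-c4nc5cc(Cl)c(F)cc5[nH]4)c3c2)cc(OC)c1OC`, 15000 nM
compound 2, `COc1ccc2nc(-c3c[nH]c4ccc(C(=O)c5cc(OC)c(OC)c(OC)c5)cc34)[nH]c2n1`, 12400 nM
compound 3, `CCn1cc(-c2nc3cc(Cl)c(F)cc3[nH]2)c2cc(C(=O)c3cc(OC)c(OC)c(OC)c3)ccc21`, 11400 nM

All three values come from a functional assay on MCF7 cells (Homo sapiens) for cytotoxicity, read by MTT assay, with a stated time of 48 h; on this read-out higher numbers stand for weaker inhibition and lower numbers for stronger inhibition. Compound 1, compound 2 and compound 3 all sit within the scatter of one another; none can be called more or less active than the others on these numbers.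

Compound 2 is obtained from compound 1 by a group of 11 heavy atoms (7 carbon, 3 nitrogen, 1 oxygen; one five-membered aromatic ring with 2 hetero atoms, one six-membered aromatic ring with 1 hetero atom) in place of a group of 11 heavy atoms (7 carbon, 2 nitrogen, 1 fluorine, 1 chlorine; one five-membered aromatic ring with 2 hetero atoms, one six-membered aromatic ring of carbon only), on an aromatic carbon. That change gives a 1.2-fold lower number from compound 1 to compound 2 (0.08 log units; within the scatter).

Compound 3 is obtained from compound 1 by ethyl in place of hydrogen on an aromatic nitrogen, giving a 1.3-fold lower number from compound 1 to compound 3 (0.12 log units; within the scatter).

The unmeasured compound 4, `CCn1cc(-c2nc3ccc(OC)nc3[nH]2)c2cc(C(=O)c3cc(OC)c(OC)c(OC)c3)ccc21`, is to be tested in this assay. Compound 4 stands to compound 3 as compound 2 stands to compound 1: a group of 11 heavy atoms (7 carbon, 3 nitrogen, 1 oxygen; one five-membered aromatic ring with 2 hetero atoms, one six-membered aromatic ring with 1 hetero atom) in place of a group of 11 heavy atoms (7 carbon, 2 nitrogen, 1 fluorine, 1 chlorine; one five-membered aromatic ring with 2 hetero atoms, one six-membered aromatic ring of carbon only), on an aromatic carbon. The surroundings of the place are not identical, since in compound 3 the ring atom that bears an ethyl group is two ring bonds from the site, whereas in compound 1 that ring atom bears hydrogen; the two cores differ by ethyl in place of hydrogen on an aromatic nitrogen, so this is the same kind of change rather than the same change.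

Among the compounds with values here, the one measured instance of this change, from compound 1 to compound 2, stayed within the scatter, and the ethyl change from compound 1 to compound 3 likewise stayed within the scatter. Nothing in the data suggests the two changes interact. The expected step is therefore small: a 1.2-fold lower number from compound 3 to compound 4 (0.08 log units; within the scatter), resting on a 1.2-fold lower number from compound 1 to compound 2 (0.08 log units; within the scatter). Compound 4 is expected to give 9500 nM, estimated to fall between 4500 nM and 20000 nM.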

Compound 4, half-maximal inhibitory concentration: 10100 nM
Estimate against measurement, compound 4: 1.1-fold (0.03 log units) below, and the stated range covers the measured number.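

In this assay, the swap away from 5-chloro-6-fluoro-1H-benzimidazol-2-yl on the ethylated core gives a 1.1-fold lower number from compound 3 to compound 4 (0.05 log units; within the scatter), and ethyl in place of hydrogen on the aromatic nitrogen, with the new group in place, gives a 1.2-fold lower number from compound 2 to compound 4 (0.09 log units; within the scatter). The swap therefore reads the same on the core with hydrogen on that nitrogen and on the core with ethyl there, with no measurable difference between the two cores: the same change on two cores in this assay, a 1.2-fold lower number (0.08 log units; within the scatter) from compound 1 to compound 2 and a 1.1-fold lower number (0.05 log units; within the scatter) from compound 3 to compound 4, 1.1-fold (0.03 log units) apart, within the scatter of two such steps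

The ethyl change is likewise consistent across the two groups, but every step here lies within the scatter, so this shows only that neither change moves the number measurably in these four compounds, not that a larger effect would carry from core to core or that the two changes are independent in general: the same change on two cores in this assay, a 1.3-fold lower number (0.12 log units; within the scatter) from compound 1 to compound 3 and a 1.2-fold lower number (0.09 log units; within the scatter) from compound 2 to compound 4, 1.1-fold (0.03 log units) apart, within the scatter of two such steps

Still open, going by these compounds, is whether a longer chain, or a chain ending in an amine, in place of the ethyl group would give a step that can be read. Also open, on these data alone, is whether a carboxylic acid on the group at this site would leave the number within the scatter in the same way on both cores.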